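Compound 4: replacing dimethylamino with diethylamino

The compounds below may be only part of what the source reports. "The series", "measured", "known", "first", "only" and "open" are said of these compounds alone.

Measured in a functional assay on A549 cells (Homo sapiens) for cytotoxicity, read by CCK-8 assay; a lower number here means a stronger inhibitor, a higher number a weaker inhibitor:
Compound 1 `O=C(Nc1ccc(O)cc1)c1ncc(-c2ccccc2)o1`: 1080 nM
Compound 2 `COc1ccc(NC(=O)c2ncc(-c3ccccc3)o2)cc1`: > 30000 nM (a limit)
Compound 3 `CN(C)c1ccc(NC(=O)c2ncc(-c3ccccc3)o2)cc1`: > 30000 nM (a limit)

Compound 3 stands at the limit of > 30000 nM in this assay, at which 2 of the 3 values shown sit. Its reading of > 30000 nM is a limit and not a number. Only compound 1 gives a true number in this assay, at 1080 nM.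

Compound 4 `CCN(CC)c1ccc(NC(=O)c2ncc(-c3ccccc3)o2)cc1` has diethylamino in place of dimethylamino on an aromatic carbon.

Two measured steps at this place are large: an at least 27-fold higher number from compound 1 to compound 2 (1.44 log units; beyond the scatter), and an at least 27-fold higher number from compound 1 to compound 3 (1.44 log units; beyond the scatter). Both start from the hydroxy of compound 1, so neither compares groups like the two exchanged here. The closest step, a step that the two limits leave unreadable from compound 2 to compound 3, cannot be sized. For the measured compounds named here, no measured step changes the groups on this nitrogen.

The change is therefore not expected to restore activity, and no step beyond the scatter is expected in either direction. The estimated change is a step that the limit leaves unreadable from compound 3 to compound 4, and a reading that is again only a limit is the likeliest outcome. For compound 4 the estimate is 35000 nM, with an expected range from 12000 nM to 100000 nM.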

Compound 4, half-maximal inhibitory concentration: > 30000 nM
Compound 4 was reported as a limit (the forecaster's own chance of this, stated with the estimate: 80%); the middle value is on the limit's open side.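

In this assay, diethylamino in place of dimethylamino does not bring back a true number, so the larger group on this nitrogen ends where the smaller one did, at the limit of the assay: the limit of > 30000 nM in this assay, at which 3 of the 4 values shown sit. Diethylamino in place of the hydroxy of compound 1 gives an at least 27-fold higher number from compound 1 to compound 4 (1.44 log units; beyond the scatter), and this is a third large step away from that hydroxy, alongside those to methoxy and dimethylamino. The steps among compound 2, compound 3 and compound 4 cannot be read, so no order can be given among these three.

The compounds shown leave open whether any group other than hydroxy at this place can give a true number in this assay. An unsubstituted amine or a carboxylic acid there would speak to that question.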